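Sulfur substituent in the riboside pair: benzyl to methyl

The source may report more compounds than this note shows. Statements on the series, on what has been measured and on what is new or still open speak of the compounds shown alone.

Three compounds have been run in a functional assay on EL4 cells (Mus musculus) for inhibition, tested at 100 uM; a higher number here means more inhibition at the concentration tested (going by the name of the read-out), a lower number less inhibition. Compound 2 `OC[C@H]1OC(n2cnc3c(SCc4ccccc4)nccc32)[C@H](O)[C@@H]1O` gives 30% in this assay, the highest of the two plain numbers shown. Compound 3 `[O-][n+]1ccc2[nH]cnc2c1` gives 5% in this assay, which lies beyond the usual scatter below compound 2. Compound 1 `CSc1[nH]ccc2ncnc1-2` shows only < 5% in this assay; this is a limit of the assay, not a number. Compound 1 thus sits at the limit of < 5% in this assay, at which 1 of the 3 values shown sits.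

Compound 4 `CSc1nccc2c1ncn2C1O[C@H](CO)[C@@H](O)[C@H]1O` is not yet measured in this assay. It differs from compound 2 by hydrogen in place of phenyl on a saturated chain carbon bound to a sulfur. Going by the values given here, no measured step of this kind exists among the three compounds. Compound 1, which carries the same methylsulfanyl group on its core, gives only a limit, so the change is expected to cost inhibition. The step from compound 2 to compound 4 is expected to be a drop beyond the scatter, a number 22 percentage points lower from compound 2 to compound 4 (beyond the scatter). Compound 4 is therefore estimated at 8%, with a range from 0% to 22% in this assay.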

Compound 4, a percentage reported as inhibition, at one concentration (the size of the read-out at that concentration, not a potency): < 5%
Compound 4 was reported as a limit; the forecaster's own chance of this, stated with the estimate: 35%; middle value at least 3 percentage points from the limit.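

In this assay, going by these compounds alone, the riboside pair now gives the first measured step at this position: going from benzylsulfanyl to methylsulfanyl, hydrogen in place of phenyl on a saturated chain carbon bound to a sulfur, gives a number at least 25 percentage points lower from compound 2 to compound 4 (beyond the scatter). Compound 4 gives < 5%, which is a limit of the assay. The phenyl therefore matters in this pair, as the riboside without it no longer gives a number and joins the lowest reading in the series: the limit of < 5% in this assay, at which 2 of the 4 values shown sit.

From the compounds shown here alone, the true size of the step stays open, as it rests on a limit. The compounds shown also cannot separate a need for the phenyl ring itself from a need for a larger group in place of methyl, which a cyclohexylmethyl group or a longer alkyl chain in the same place would address.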